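Removing the Chloro Group from Compound 3

The source may report more compounds than this note shows. Statements on the series, on what has been measured and on what is new or still open speak of the compounds shown alone.

Compound 3 `O=c1c(C2N=C(c3ccccc3)SS2)coc2cc(Cl)ccc12` gives the highest of the three numbers in a functional assay on COLO 205 cells (Homo sapiens) for inhibition, read by sulforhodamine B assay, with a stated time of 48 h, tested at 100 uM (on this read-out higher numbers stand for more inhibition of growth at the one concentration tested and lower numbers for less inhibition of growth), namely 57%. Compound 1 `Cc1ccc2occ(C3N=C(c4ccccc4)SS3)c(=O)c2c1` gives 32% in this assay, and compound 2 `O=c1c(C2N=C(c3ccccc3)SS2)coc2ccc(Cl)cc12` gives 12%. Among the compounds with values here, the one measured step, a number 20 percentage points lower from compound 1 to compound 2 (beyond the scatter), exchanges one substituent for another on the shared core and does not remove a group. Compound 4 `O=c1c(C2N=C(c3ccccc3)SS2)coc2ccccc12` differs from compound 3 by hydrogen in place of chloro on an aromatic carbon. Within the data shown here, no measured step removes a chloro, so the direction of this change cannot be read from the data; the two chloro compounds, compound 2 and compound 3, show values far apart. A step of a number 22 percentage points lower from compound 3 to compound 4 (beyond the scatter) is expected, placing the unsubstituted compound between them. Compound 4 is estimated at 35%, within 10% to 60%.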

Compound 4, percent growth inhibition at one concentration: 18%
Compound 4: middle estimate off by 17 percentage points, on the high side; the range from low to high includes it.
By their numbers in this assay, from the lowest: compounds 2 and 4 (each within the scatter of the next); then compound 1; then compound 3.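

In this assay the chloro of compound 3 carries much of the number, with a number 39 percentage points lower from compound 3 to compound 4 (beyond the scatter) on its loss from the aromatic carbon meta to a fused ring and para to a fused ring. Hydrogen in place of the chloro of compound 2 gives a number 6 percentage points higher from compound 2 to compound 4 (within the scatter) and so no difference that can be told apart, while hydrogen in place of the methyl of compound 1 gives a number 14 percentage points lower from compound 1 to compound 4 (beyond the scatter) as a modest loss. Nothing at hand explains why the chloro matters in compound 3 but not in compound 2. As far as these compounds go, how a methoxy group or an amine on that aromatic carbon would compare with the chloro of compound 3 stays open.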